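Iodine for Bromine on a Shared Core

A few compounds are considered here, and "the series" means these few. Any claim that something is new, unique, unknown or untested is made for them only; others in the source may bear on it.

Within the data shown here, compound 1 `CCC[C@@H](OC(C)=O)C1=C(Br)/C(=C/Br)OC1=O` gives 2.1 ug/mL in a functional assay on KB cells (Homo sapiens) for cytotoxicity (a higher number here means that more compound is needed for the effect, a lower number that less compound is needed), the lower of the two numbers measured so far. Its nearest neighbour, compound 2 `CCC[C@@H](O)C1=C(Br)/C(=C/Br)OC1=O`, carries hydrogen in place of acetyl on an oxygen on a saturated carbon and gives 3.4 ug/mL in this assay. The resulting step, a 1.6-fold higher number from compound 1 to compound 2 (0.21 log units; within the scatter), shows that this change makes little difference. Compound 3 `CCC[C@@H](OC(C)=O)C1=C(Br)/C(=C/I)OC1=O` keeps the acetyl of compound 1 and instead carries iodo in place of bromo on a double-bonded chain carbon bound to a double-bonded ring carbon. Among the measured compounds shown here, no measured step touches either halogen, so this change has no direct precedent; the only step available concerns a different part of the molecule and offers no guidance in either direction. The analyst therefore expects compound 3 to land close to compound 1, with a 1.1-fold lower number from compound 1 to compound 3 (0.02 log units; within the scatter) staying within the scatter. The expected value for compound 3 in this assay is 2 ug/mL, within a range from 0.9 ug/mL to 4.5 ug/mL.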

Compound 3, concentration for half-maximal effect: 3.6 ug/mL
Estimate against measurement, compound 3: 1.8-fold (0.26 log units) below; the range from low to high includes it.
By their numbers in this assay, from the lowest: compounds 1, 2 and 3 (each within the scatter of the next).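

At the double-bonded chain carbon bound to a double-bonded ring carbon, iodo in place of bromo gives, in this assay, a 1.7-fold higher number from compound 1 to compound 3 (0.23 log units; within the scatter), so exchanging one halogen for the other at this place makes little difference to the number. Among these compounds, this is the only step that touches this place, and it joins a 1.6-fold higher number from compound 1 to compound 2 (0.21 log units; within the scatter) at the acetyl: neither of the two changes on the shared core goes beyond the scatter. Nothing measured on these compounds offers an explanation for this result.

The compounds shown leave open whether chloro or plain hydrogen at this same place would move the number beyond the scatter, as only bromo and iodo appear there. They also leave open what an amine, a carboxylic acid or a longer chain on the shared core would do.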